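The source may report more compounds than this note shows. Statements on the series, on what has been measured and on what is new or still open speak of the compounds shown alone.

Measured in a functional assay on T47D cells (Homo sapiens) for inhibition, read by CCK-8 assay, with a stated time of 72 h, tested at 1 uM; a higher number here means more inhibition of growth at the concentration tested, a lower number less inhibition of growth:
- compound 1 `CN(C)C(=O)c1cc2cnc(Nc3ccc(NC(=O)C4(C(=O)Nc5ccc(F)cc5)CC4)cc3)nc2n1C1CCCC1`: 74.7%
- compound 2 `CN(C)C(=O)c1cc2cnc(Nc3ccc(NC(=O)C4(C(=O)Nc5ccc(Cl)c(C(F)(F)F)c5)CC4)cc3)nc2n1C1CCCC1`: 6.9%

Compound 2 holds the lower of the two numbers, at 6.9%. Compound 3 `CN(C)C(=O)c1cc2cnc(Nc3ccc(NC(=O)C4(C(=O)Nc5cccc(Br)c5)CC4)cc3)nc2n1C1CCCC1` has 3-bromophenyl in place of 4-chloro-3-(trifluoromethyl)phenyl on an amide-type nitrogen. Within the data shown here, the only measured step at this place is a number 67.8 percentage points lower from compound 1 to compound 2 (beyond the scatter), a large one. Compound 3 gives up the group that arrived with that step, but does not return to 4-fluorophenyl. Partial recovery is therefore expected in this assay, upward and beyond the scatter, though one step gives weak guidance. The expected move is a number 33.1 percentage points higher from compound 2 to compound 3 (beyond the scatter). The estimated value for compound 3 is 40%, with an expected range of 13% to 72%.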

Compound 3, percent growth inhibition at one concentration: 29.1%
Beside the measured number, compound 3's estimate is 10.9 percentage points above it; measured number inside the range.
By their numbers in this assay, from the lowest: compound 2; then compound 3; then compound 1.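

At the amide-type nitrogen, 3-bromophenyl reads at an intermediate level in this assay: replacing 4-chloro-3-(trifluoromethyl)phenyl gives a number 22.2 percentage points higher from compound 2 to compound 3 (beyond the scatter) and replacing 4-fluorophenyl gives a number 45.6 percentage points lower from compound 1 to compound 3 (beyond the scatter). This position therefore yields three separated levels, not just a two-way contrast, with 4-fluorophenyl highest among these compounds. No measurement on hand explains this order.
Still open, going by these compounds, is whether the identity of the halogen or its place on the phenyl ring sets the level, which 4-bromophenyl could help separate. Also open, on these data alone, is how a phenyl ring carrying an amine or a carboxylic acid would read.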